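The compounds below may be only part of what the source reports. "The series", "measured", "known", "first", "only" and "open" are said of these compounds alone.

Of the compounds shown here, three sharing one core have been measured in an in vitro ADME assay on microsomes from liver (Mus musculus) for pharmacokinetics, read by LC-MS, with a stated time of 10 min, tested at 1 uM; a lower number here means slower removal, a higher number faster removal of the compound: compound 1 (`COc1ccc(NC(=O)[C@H]2CN(C)C[C@@H]2c2ccc(/C=C/C(=O)Nc3ccccc3N)cc2)cc1`) gives 54 mL/min/kg, compound 2 (`CN1C[C@H](C(=O)Nc2cccc(F)c2)[C@@H](c2ccc(/C=C/C(=O)Nc3ccccc3N)cc2)C1`) gives 56 mL/min/kg, and compound 3 (`CN1C[C@H](C(=O)Nc2ccc(F)c(Cl)c2)[C@@H](c2ccc(/C=C/C(=O)Nc3ccccc3N)cc2)C1`) gives 34 mL/min/kg. Compound 3 stands within the scatter of both others, so the three values do not separate.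

Compound 4 (`CN1C[C@H](C(=O)Nc2ccc(Cl)cc2F)[C@@H](c2ccc(/C=C/C(=O)Nc3ccccc3N)cc2)C1`) is next: 4-chloro-2-fluorophenyl in place of 3-chloro-4-fluorophenyl on an amide-type nitrogen. It has the same atoms as compound 3, joined differently, with 4-chloro-2-fluorophenyl in place of 3-chloro-4-fluorophenyl on an amide-type nitrogen.

The measured changes at this nitrogen are the relevant evidence: a 1.0-fold higher number from compound 1 to compound 2 (0.02 log units; within the scatter), a 1.6-fold lower number from compound 1 to compound 3 (0.20 log units; within the scatter) and a 1.6-fold lower number from compound 2 to compound 3 (0.22 log units; within the scatter). All three lie within the scatter. None of them, however, keeps the same atoms while joining them differently, so the comparison is indirect. No step beyond the scatter is therefore expected in this assay, and no direction can be assigned.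

The estimated change is a 1.2-fold higher number from compound 3 to compound 4 (0.09 log units; within the scatter). Compound 4 is expected at 42 mL/min/kg, with an estimated range of 24 mL/min/kg to 70 mL/min/kg.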

Compound 4, clearance: 43 mL/min/kg
Estimate against measurement, compound 4: 1.0-fold (0.01 log units) below; the measured number falls inside the stated range.
By their numbers in this assay, from the lowest: compounds 3, 4, 1 and 2 (each within the scatter of the next).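

In this assay the same atoms are rearranged on the amide-type nitrogen, with 4-chloro-2-fluorophenyl in place of 3-chloro-4-fluorophenyl, and this first direct reading of such a change gives (a 1.3-fold higher number from compound 3 to compound 4 (0.10 log units; within the scatter)), within the scatter. Compound 4 also stays within the scatter of the other two compounds (a 1.3-fold lower number from compound 2 to compound 4 (0.11 log units; within the scatter); a 1.3-fold lower number from compound 1 to compound 4 (0.10 log units; within the scatter)), so the four substituted phenyl amides still do not separate at this position. Nothing available accounts for these numbers.

All four compounds carry a substituted phenyl group on this nitrogen, so the reading does not extend to an unsubstituted phenyl, a pyridyl ring, a cyclohexyl group or an alkyl chain. From the compounds shown here alone, whether any such group would produce a step beyond the scatter in this assay remains open.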